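Compound 2 to compound 3, starting from a limit

A few compounds are considered here, and "the series" means these few. Any claim that something is new, unique, unknown or untested is made for them only; others in the source may bear on it.

Measured in an ADME assay on HEK293 cells (Homo sapiens) for cytotoxicity, with a stated time of 72 h; a higher number here means that more compound is needed for the effect, a lower number that less compound is needed:
- Compound 1 `C=C[C@@](C)(/C=C/c1ccc(Nc2ccccc2)cc1)CCC=C(C)C`: > 36600 nM (a limit)
- Compound 2 `C=C[C@@](C)(/C=C/c1ccc(Nc2cc(F)cc(F)c2)cc1)CCC=C(C)C`: > 36600 nM (a limit)

Compound 2 stands only at a limit, > 36600 nM. Both measured values share it: the limit of > 36600 nM in this assay, at which 2 of the 2 values shown sit. Going by the values given here, the only measured step bearing on the change is a step that the two limits leave unreadable from compound 1 to compound 2.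

Compound 3 `C=C[C@@](C)(/C=C/c1ccc(Nc2ccc(Cl)c(F)c2)cc1)CCC=C(C)C` is not yet measured. It differs from compound 2 as follows: 4-chloro-3-fluorophenyl in place of 3,5-difluorophenyl on a nitrogen on an aromatic ring. With no readable step to go on, no change beyond the scatter is expected in this assay, in either direction. For compound 3 the estimated value is 40000 nM, with an expected range of 20000 nM to 80000 nM. This estimate means an expected step that the limit leaves unreadable from compound 2 to compound 3.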

Compound 3, half-maximal effective concentration: > 36600 nM
Compound 3 gave a limit, no number (the forecaster's own chance of this, stated with the estimate: 75%); the middle value lies beyond the limit too.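

No step among compound 1, compound 2 and compound 3 can be read, since all three stand at a limit: the limit of > 36600 nM in this assay, at which 3 of the 3 values shown sit.

The compounds shown leave open whether the phenyl, 3,5-difluorophenyl and 4-chloro-3-fluorophenyl groups differ at all in this assay.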